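Five-membered heteroaryl swap on the shared core of compound 1

A few compounds are considered here, and "the series" means these few. Any claim that something is new, unique, unknown or untested is made for them only; others in the source may bear on it.

For the measured compounds named here, in a functional assay on MV4-11 cells (Homo sapiens) for inhibition, read by resazurin assay, with a stated time of 72 h (on this read-out lower numbers stand for stronger inhibition of growth and higher numbers for weaker inhibition of growth), compound 1 `O=C1NCCC12CCN(c1c(Cl)cncc1-c1ccoc1)CC2` gives 750 nM, which is the highest of the two numbers so far; its nearest neighbour is compound 2 `O=Cc1cc(-c2cncc(Cl)c2N2CCC3(CCNC3=O)CC2)cs1`, which gives 730 nM in this assay, and the step of a 1.0-fold lower number from compound 1 to compound 2 (0.01 log units; within the scatter) lies within the scatter. Compound 3 `O=C1NCCC12CCN(c1c(Cl)cncc1-c1cn[nH]c1)CC2` is not yet measured in this assay. It differs from compound 1 in one place: 1H-pyrazol-4-yl in place of furan-3-yl on an aromatic carbon. Going by the values given here, the only measured step that bears on this change is the one from compound 1 to compound 2, where another five-membered aromatic ring replaced furan-3-yl on the same aromatic carbon and the number moved by a 1.0-fold lower number from compound 1 to compound 2 (0.01 log units; within the scatter), not beyond the scatter. Among the compounds with values here, on that basis no step beyond the scatter is expected from compound 1 to compound 3 in this assay, with the width of the range reflecting that only one comparable step exists; the expected step is a 1.2-fold lower number from compound 1 to compound 3 (0.06 log units; within the scatter). Compound 3 is estimated at 650 nM in this assay, within a range from 220 nM to 2000 nM.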

Compound 3, concentration for 50% growth inhibition: 8520 nM
Estimate against measurement, compound 3: 13-fold (1.12 log units) below; the measured number lies above the stated range.
By their numbers in this assay, from the lowest: compounds 2 and 1 (each within the scatter of the next); then compound 3.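

In this assay, this position on the shared core clearly distinguishes between five-membered aromatic rings, although the earlier pair showed no step beyond the scatter: 1H-pyrazol-4-yl in place of furan-3-yl gives (an 11-fold higher number from compound 1 to compound 3 (1.06 log units; beyond the scatter)), and 1H-pyrazol-4-yl in place of 5-formylthiophen-3-yl gives (a 12-fold higher number from compound 2 to compound 3 (1.07 log units; beyond the scatter)). At the same count of 5 heavy atoms, 1H-pyrazol-4-yl carries 1 hydrogen-bond donor and 2 hetero atoms where furan-3-yl carries 0 and 1, but this single swap cannot show which of these differences goes with the step. Nothing available on these compounds accounts for the step.

Going by these compounds, it remains open whether 1-methyl-1H-pyrazol-4-yl, with a methyl group on the ring nitrogen, or a six-membered ring such as phenyl would give numbers close to those of compound 1 and compound 2 or close to that of compound 3. On these data alone, all three compounds also keep the chloro group and the rest of the core unchanged, so it is open whether a step of this size would persist with an amine or a methoxy group in place of that chloro group.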